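Trading methylsulfanyl for nitro on the shared core

The compounds below may be only part of what the source reports. "The series", "measured", "known", "first", "only" and "open" are said of these compounds alone.

Of the compounds shown here, three built on one core have been measured in an assay for inhibition of cytokinin dehydrogenase 2 (Arabidopsis thaliana); on this read-out lower numbers stand for stronger inhibition and higher numbers for weaker inhibition. Compound 1 `COc1cccc(Nc2nc(F)nc3[nH]cnc23)c1` gives 1000 nM. Compound 2 `COc1cccc(Nc2nc(N)nc3[nH]cnc23)c1` gives 27000 nM. Compound 3 `COc1cccc(Nc2nc(SC)nc3[nH]cnc23)c1` reaches only a limit of the assay, > 100000 nM, so only a bound is known for it; that bound is the limit of > 100000 nM in this assay, at which 1 of the 3 values shown sits. Thus compound 3 stands at the weak end of what has been seen: the change from compound 1 was an at least 100-fold higher number from compound 1 to compound 3 (2.00 log units; beyond the scatter) and from compound 2 was an at least 3.7-fold higher number from compound 2 to compound 3 (0.56 log units; beyond the scatter), while between the two numbered compounds the step was a 27-fold higher number from compound 1 to compound 2 (1.43 log units; beyond the scatter).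

Compound 4 `COc1cccc(Nc2nc([N+](=O)[O-])nc3[nH]cnc23)c1` differs from compound 3 by nitro in place of methylsulfanyl on an aromatic carbon. Going by the values given here, no measured step involves nitro, so the bearing is indirect: both steps that removed methylsulfanyl, the one of an at least 100-fold higher number from compound 1 to compound 3 (2.00 log units; beyond the scatter) and the one of an at least 3.7-fold higher number from compound 2 to compound 3 (0.56 log units; beyond the scatter), were large when read toward compound 3, and every group seen in its place gave a lower number. Compound 4 is therefore expected to show a step of an at least 25-fold lower number from compound 3 to compound 4 (1.39 log units; beyond the scatter), a lower number than the bound of compound 3. Compound 4 is estimated at 4000 nM, with a range from 500 nM to 50000 nM.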

Compound 4, half-maximal inhibitory concentration: 14000 nM
Compound 4: middle estimate off by 3.5-fold (0.54 log units), on the low side; measured number inside the range.
By their numbers in this assay, from the lowest: compound 1; then compounds 4 and 2 (each within the scatter of the next). At a limit, above all of these: compound 3.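

At this position, between two ring nitrogen atoms, nitro brings the compound back from the limit that methylsulfanyl reached in this assay, but that step is only a bound, an at least 7.1-fold lower number from compound 3 to compound 4 (0.85 log units; beyond the scatter), because compound 3 stands at a limit: the limit of > 100000 nM in this assay, at which 1 of the 4 values shown sits.

Nitro and amino cannot be told apart here, a 1.9-fold lower number from compound 2 to compound 4 (0.29 log units; within the scatter), so two groups that differ in atom count and in make-up give values within the scatter of each other. Fluoro stays clearly ahead of nitro, a 14-fold higher number from compound 1 to compound 4 (1.15 log units; beyond the scatter), which leaves compound 1, with its steps to all three others beyond the scatter, as the strongest inhibitor of the four in this assay.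

The compounds shown leave open how chloro or a bare hydrogen would fare at this position, and whether any group there could give a number lower than that of compound 1. They also leave open the true size of the step away from methylsulfanyl, and whether these steps would hold if the methoxy group of the shared core gave way to a hydroxyl.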